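Losing the Formyl from Compound 2

The source may hold more compounds than are shown below. What is called first, only, known or untested is meant among the compounds shown, and "the series" means these compounds.

Measured so far in an ADME assay on BJ cells (Homo sapiens) for cytotoxicity, with a stated time of 72 h; a lower number here means that less compound is needed, a higher number that more compound is needed for the effect:
- compound 1 `C=C[C@@](C)(/C=C/c1ccc(OS(=O)(=O)C(F)(F)F)cc1)CCC=C(C)C`: > 36600 nM (a limit)
- compound 2 `COc1ccc(/C=C/[C@@](C)(/C=C/c2ccc(O)c(C=O)c2)CCC=C(C)C)cc1`: 9800 nM

Going by the values given here, compound 2 at 9800 nM holds the only exact number so far. Compound 3 `COc1ccc(/C=C/[C@@](C)(/C=C/c2ccc(O)cc2)CCC=C(C)C)cc1` has not been measured. It differs from compound 2 by hydrogen in place of formyl on an aromatic carbon. Among the compounds with values here, no measured pair shows this change directly. Compound 1, which also has no formyl, stands at the limit > 36600 nM of this assay and gives the only hint. A modest upward step is expected, estimated as a 2.2-fold higher number from compound 2 to compound 3 (0.35 log units; beyond the scatter) (more compound needed). Compound 3 is expected at 22000 nM (estimated range 9000 nM to 45000 nM).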

Compound 3, half-maximal effective concentration: > 36600 nM
Compound 3 gave a limit, no number (the forecaster's own chance of this, stated with the estimate: 35%); middle value at least 1.6-fold (0.22 log units) away from the limit.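

In this assay, the formyl ortho to a hydroxy group now has a direct comparison: replacing it with hydrogen gives an at least 3.7-fold higher number from compound 2 to compound 3 (0.57 log units; beyond the scatter). The earlier compounds shown here offered only a hint, since compound 1 differs from compound 2 in more than one place. Only the minimum size of this step can be read, because compound 3 gives a limit rather than a number: the limit of > 36600 nM in this assay, at which 2 of the 3 values shown sit.

Going by these compounds, whether a carboxylic acid, an acetyl group or a hydroxymethyl group on this carbon would keep the number near that of compound 2 stays open. On these data alone, it also remains open whether the same change would have a similar effect on another core.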